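The source may hold more compounds than are shown below. What is called first, only, known or untested is meant among the compounds shown, and "the series" means these compounds.

Compound 1, `COc1ccc(-c2cc(=O)c3c(OC)cc(OC)cc3n2S(=O)(=O)c2ccc(Cl)cc2)cc1`, in a functional assay on KOPN-8 cells (Homo sapiens) for antiproliferative activity, with a stated time of 72 h (a lower number here means that less compound is needed, a higher number that more compound is needed for the effect), gives only a limit of the assay, > 34400 nM.
Compound 2, `COc1ccc(-c2cc(=O)c3c(OC)cc(OC)cc3n2S(=O)(=O)c2ccc(Br)cc2)cc1`, in this assay gives only a limit as well, > 86200 nM.

Going by the values given here, compound 2 therefore stands at a limit and not at a number, and the one further value shown, that of compound 1, is a limit too. Among the compounds with values here, the single measured step, a step that the two limits leave unreadable from compound 1 to compound 2, cannot be read in size because its two ends are the limit of > 34400 nM in this assay, at which 1 of the 2 values shown sits, and (the limit of > 86200 nM in this assay, at which 1 of the 2 values shown sits).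

Compound 3, `COc1ccc(-c2cc(=O)c3c(OC)cc(OC)cc3n2S(=O)(=O)c2ccc(OC)cc2)cc1`, differs from compound 2 by methoxy in place of bromo on an aromatic carbon. Within the data shown here, no measured step with a readable size bears on this change, so the size of the step in this assay cannot be read from the measured compounds. With both measured compounds at limits, the expected step is an at least 1.4-fold lower number from compound 2 to compound 3 (0.15 log units; that floor lies within the scatter), taken as no change beyond the scatter. Compound 3 is therefore estimated at 60000 nM, with a range from 10000 nM to 300000 nM, most likely reported again only as a limit.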

Compound 3, half-maximal effective concentration: > 82700 nM
Compound 3: only a limit was reported (the forecaster's own chance of this, stated with the estimate: 75%); at least 1.3-fold (0.13 log units) between middle value and limit.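

Going by these compounds alone, compound 1, compound 2 and compound 3 all give only limits in this assay, so no step among them can be read in size. Going by these compounds, whether chloro, bromo or methoxy on this aromatic carbon makes any difference to the concentration needed remains open.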